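From methyl to butoxy on compound 1

A few compounds are considered here, and "the series" means these few. Any claim that something is new, unique, unknown or untested is made for them only; others in the source may bear on it.

Three compounds on a shared core have readings so far in a functional assay on HepG2 cells (Homo sapiens) for cytotoxicity (a higher number here means a weaker inhibitor, a lower number a stronger inhibitor), for comparison. Compound 1 (`Cc1ccc(S(=O)(=O)N/C(=N\O)Nc2ccc(Cl)cc2)cc1`) stands at 49 ug/mL and compound 3 (`O=S(=O)(N/C(=N\O)Nc1ccc(Cl)cc1)c1cccc2snnc12`) at 45 ug/mL on the same level, as the two lie within the scatter of each other. Compound 2 (`O=S(=O)(N/C(=N\O)Nc1ccc(Cl)cc1)c1cc2ccccc2o1`) reads > 200 ug/mL as a limit of the assay and not a number.

Compound 4 (`CCCCOc1ccc(S(=O)(=O)N/C(=N\O)Nc2ccc(Cl)cc2)cc1`) has not yet been measured. It keeps the core of compound 1 and differs in one place: butoxy in place of methyl on an aromatic carbon describes butoxy in place of methyl on an aromatic carbon, para to a large group.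

Among the compounds with values here, no measured pair differs in one place only, so the size of this change cannot be read directly from the data. The closest guide is that compound 1 at 49 ug/mL and compound 3 at 45 ug/mL sit level despite carrying different groups. On that basis, only a small change is expected in this assay and it should stay within the scatter, leaning toward a lower number. The expected step is a 1.4-fold lower number from compound 1 to compound 4 (0.15 log units; within the scatter) on this estimate. Compound 4 is estimated at 35 ug/mL with 12 ug/mL to 110 ug/mL as the expected range.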

Compound 4, half-maximal inhibitory concentration: 63 ug/mL
Estimate against measurement, compound 4: 1.8-fold (0.26 log units) below, and the stated range covers the measured number.
By their numbers in this assay, from the lowest: compounds 3, 1 and 4 (each within the scatter of the next). At a limit, above all of these: compound 2.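

In this assay, butoxy in place of methyl on an aromatic carbon, para to a large group, gives a 1.3-fold higher number from compound 1 to compound 4 (0.11 log units; within the scatter), and no other step can be read in the series. Within the data shown here, this is the first direct reading at this position: exchanging methyl for butoxy, which brings an added hydrogen-bond acceptor and a longer chain, leaves a reading that cannot be told apart from that of the methyl compound. Compound 2 alone stands at a limit, which is not a number: the limit of > 200 ug/mL in this assay, at which 1 of the 4 values shown sits.

A single step within the scatter sets no trend with chain length, and it does not separate the ether oxygen from the added carbons, as butoxy brings both at once. Methoxy or a plain butyl chain at this position would pull those two apart, while an amine or a carboxylic acid there would test whether this flat reading holds for a group of a different kind.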